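This account rests on a few compounds, and the source may have more. Where it says the series, first, only, none or still open, it means among the compounds named here.

Values measured in a functional assay on KB cells (Homo sapiens) for antiproliferative activity, read by MTT assay, with a stated time of 72 h (a lower number here means a stronger inhibitor, a higher number a weaker inhibitor), are these:

Compound 1 `COc1ccc(-c2cc(C(=O)O)sc2-c2cc(OC)c(OC)c(OC)c2)cc1` gives 8650 nM
Compound 2 `COc1ccc(-c2cc(C(=O)O)sc2-c2cc(OC)c(OC)c(OC)c2)cc1[N+](=O)[O-]` gives 43700 nM
Compound 3 `COc1ccc(-c2cc(C(=O)O)sc2-c2cc(OC)c(OC)c(OC)c2)cc1O` gives 21800 nM

Compound 2 sits at the weak end of this small set, together with compound 3, since a 2.0-fold lower number from compound 2 to compound 3 (0.30 log units; within the scatter) separates them. Compound 1 is clearly stronger than either of them.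

Compound 4 `COc1ccc(-c2ccsc2-c2cc(OC)c(OC)c(OC)c2)cc1[N+](=O)[O-]` has not been measured yet. It departs from compound 2 at a new place: hydrogen in place of carboxy on an aromatic carbon and in words this is hydrogen in place of carboxy on an aromatic carbon.

The measured steps bear on this only indirectly. Two are beyond the scatter and modest, namely a 5.1-fold higher number from compound 1 to compound 2 (0.70 log units; beyond the scatter) and a 2.5-fold higher number from compound 1 to compound 3 (0.40 log units; beyond the scatter) and both leave the carboxy untouched. All three measured compounds carry it, so no measurement shows what losing it does. Those modest steps therefore set no limit here. Removing a whole carboxy is a larger structural change than either of them, and a clear shift towards a lower number in this assay is a judgement rather than a finding. The expected move is a 55-fold lower number from compound 2 to compound 4 (1.74 log units; beyond the scatter) and its size is only loosely held. Compound 4 is estimated at 800 nM with 30 nM and 15000 nM as the expected ends of its range.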

Compound 4, half-maximal inhibitory concentration: 21000 nM
Beside the measured number, compound 4's estimate is 26-fold (1.42 log units) below it, outside the stated range (above it).
By their numbers in this assay, from the lowest: compound 1; then compounds 4, 3 and 2 (each within the scatter of the next, the first and the last beyond it).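

Going by these compounds alone, until now every compound carried the carboxy, so this is the first view of what happens when that group leaves an aromatic carbon of the five-membered aromatic ring with 1 sulfur, next to the ring sulfur. In this assay, hydrogen in place of carboxy gives a 2.1-fold lower number from compound 2 to compound 4 (0.32 log units; beyond the scatter), a modest step that lies beyond the usual scatter, so a group of 3 heavy atoms, including a hydrogen-bond donor, can go from this place while the number shifts only slightly and stays in the weak range of this set. Nothing available explains why the change in activity is this small.

The replacement is shown only on the nitro-bearing compound 2, so it remains open whether losing the carboxy would have a similarly small result on compound 1 or compound 3, which lack the nitro. The compounds shown also compare only carboxy and hydrogen at this place, which leaves open how a methyl ester, an amide or an amine would fare there.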